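Moving the Methoxy Group: A Small Step Expected

The source may hold more compounds than are shown below. What is called first, only, known or untested is meant among the compounds shown, and "the series" means these compounds.

In a functional assay on T98G cells (Homo sapiens) for inhibition, read by MTT assay, with a stated time of 72 h (a lower number here means a stronger inhibitor, a higher number a weaker inhibitor), compound 1 (`COc1ccc(NC(=S)NC2CC(C)(C)Oc3ccc(Br)cc32)cc1`) gives 33000 nM, compound 2 (`CC1(C)CC(NC(=S)Nc2cccc(C#N)c2)c2cc(Br)ccc2O1`) gives 9000 nM and compound 3 (`COc1ccccc1NC(=S)NC1CC(C)(C)Oc2ccc(Br)cc21`) gives 42000 nM. The two methoxyphenyl compounds cannot be told apart, with a 1.3-fold higher number from compound 1 to compound 3 (0.10 log units; within the scatter). The 3-cyanophenyl compound stands clear of both, with a 3.7-fold lower number from compound 1 to compound 2 (0.56 log units; beyond the scatter) on one side and a 4.7-fold higher number from compound 2 to compound 3 (0.67 log units; beyond the scatter) on the other. Compound 3 therefore sits level with compound 1 and apart from compound 2.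

Compound 4 (`COc1cccc(NC(=S)NC2CC(C)(C)Oc3ccc(Br)cc32)c1`) carries 3-methoxyphenyl in place of 2-methoxyphenyl on an amide-type nitrogen. Going by the values given here, the closest precedent is the exchange of 4-methoxyphenyl for 2-methoxyphenyl between compound 1 and compound 3, which gave a 1.3-fold higher number from compound 1 to compound 3 (0.10 log units; within the scatter). The two steps involving compound 2 concern a different group and serve only as a loose guide to the range. No step beyond the scatter is therefore expected in this assay, and the estimate is a 1.5-fold lower number from compound 3 to compound 4 (0.18 log units; within the scatter). Compound 4 is estimated at 28000 nM, with an expected range from 11000 nM to 60000 nM.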

Compound 4, half-maximal inhibitory concentration: 87000 nM
The estimate for compound 4 lay 3.1-fold (0.49 log units) below the measured number, outside the stated range (above it).
By their numbers in this assay, from the lowest: compound 2; then compounds 1 and 3 (each within the scatter of the next); then compound 4.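

The place of the methoxy group on the phenyl now counts: 3-methoxyphenyl in place of 2-methoxyphenyl gives a 2.1-fold higher number from compound 3 to compound 4 (0.32 log units; beyond the scatter) in this assay and 3-methoxyphenyl in place of 4-methoxyphenyl gives a 2.6-fold higher number from compound 1 to compound 4 (0.42 log units; beyond the scatter), although the 2-methoxyphenyl and 4-methoxyphenyl compounds stay level with each other. Methoxy in place of cyano on an aromatic carbon gives a 9.7-fold higher number from compound 2 to compound 4 (0.99 log units; beyond the scatter), the widest step among these four compounds. Nothing available explains these steps.

From the compounds shown here alone, it remains open whether the place of the nitrile on the phenyl counts as the place of the methoxy does. Going by these compounds, it also remains open how an amine or a carboxylic acid in place of the methoxy on 3-methoxyphenyl would stand against compound 2 and compound 4.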